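The compounds below may be only part of what the source reports. "The series", "measured", "known", "first", "only" and "open" are said of these compounds alone.

Measured so far:
compound 1, `OCc1cccc(-c2nc3ccccc3[nH]2)n1`, -13%
compound 2, `COc1cccc(-c2nc3ccccc3[nH]2)n1`, 47%

Among the compounds with values here, in a functional assay on the whole organism with Rattus norvegicus as the target, read by paw edema, with a stated time of 3 h, at a dose of 100 mg/kg by the oral route (a lower number here means less inhibition, a higher number more inhibition at the dose given (going by the name of the read-out)), compound 2 holds the highest of the two numbers; its only neighbour is compound 1, and the step of a number 60 percentage points higher from compound 1 to compound 2 (beyond the scatter) separates them, a large gap.

Compound 3, `NC(=O)c1cccc(-c2nc3ccccc3[nH]2)n1`, has not yet been measured. It differs from compound 2 in one place: carbamoyl in place of methoxy on an aromatic carbon. Just one measured step bears on this change: a number 60 percentage points higher from compound 1 to compound 2 (beyond the scatter), where methoxy replaced hydroxymethyl, a group with a hydrogen-bond donor, and the number rose strongly. Compound 3 brings a hydrogen-bond donor back onto the same aromatic carbon while keeping an acceptor, so a drop from compound 2 is expected, though perhaps not as deep as the level of compound 1. Compound 3 is therefore estimated at 20%, within -10% to 50%. This amounts to an expected step of a number 27 percentage points lower from compound 2 to compound 3 (beyond the scatter).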

Compound 3, a percentage reported as inhibition, in the whole organism at one dose (the size of the read-out at that dose, not a potency): 13%
Estimate against measurement, compound 3: 7 percentage points above; the measured number falls inside the stated range.
By their numbers in this assay, from the lowest: compound 1; then compound 3; then compound 2.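

Replacing methoxy with carbamoyl on this aromatic carbon in this assay gives a number 34 percentage points lower from compound 2 to compound 3 (beyond the scatter) and so shows that the response at this position does not depend only on the loss of hydroxymethyl. The comparison with the other compound carrying a hydrogen-bond donor at this position gives a number 26 percentage points higher from compound 1 to compound 3 (beyond the scatter) and shows that the two donor-bearing groups are not interchangeable here. Across these three compounds, methoxy stays ahead of both hydroxymethyl and carbamoyl, so this position clearly responds to the choice of group, though three compounds establish no general rule.

As far as these compounds go, how an amine, a carboxylic acid or the longer ethoxy group would compare on this same carbon remains open. Nothing available here accounts for the order of these groups.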